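Swapping the Triazole Diol Chain for a Piperazine Chain

The source may hold more compounds than are shown below. What is called first, only, known or untested is meant among the compounds shown, and "the series" means these compounds.

In a functional assay on HCT-116 cells (Homo sapiens) for cytotoxicity, read by MTT assay, with a stated time of 72 h (on this read-out higher numbers stand for weaker inhibition and lower numbers for stronger inhibition), compound 1 `O=C1c2c[n+]([O-])c3ccccc3c2C(=O)c2c1c1ccccc1n2Cc1cn(C[C@H](O)CO)nn1` gives 400 nM and compound 3 `O=C1c2c[n+]([O-])c3ccccc3c2C(=O)c2c1c1ccccc1n2Cc1cn(CC(O)CO)nn1` gives 250 nM, two values that belong together, while compound 2 `CC1(C)OCC(Cn2cc(Cn3c4c(c5ccccc53)C(=O)c3c[n+]([O-])c5ccccc5c3C4=O)nn2)O1` gives the lowest number (70 nM). Compound 3 thus stands level with compound 1 (a 1.6-fold lower number from compound 1 to compound 3 (0.20 log units; within the scatter)), and the only difference between the two is the fact that one of compounds 1 and 3 is drawn with a defined configuration and the other without, at the place where they differ in the drawing.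

Compound 4 `O=C1c2c[n+]([O-])c3ccccc3c2C(=O)c2c1c1ccccc1n2CCCCN1CCNCC1` keeps the shared core but exchanges the side chain 3-(piperazin-1-yl)propyl in place of 1-(2,3-dihydroxypropyl)-1H-1,2,3-triazol-4-yl on a saturated chain carbon bound to an aromatic nitrogen so that a 4-(piperazin-1-yl)butyl chain sits on the aromatic nitrogen in place of the (1-(2,3-dihydroxypropyl)-1H-1,2,3-triazol-4-yl)methyl chain.

For the measured compounds named here, two measured steps bear on this, though only loosely. They are a 5.7-fold lower number from compound 1 to compound 2 (0.76 log units; beyond the scatter) and a 3.6-fold higher number from compound 2 to compound 3 (0.55 log units; beyond the scatter), and both show that a change in this side chain can move the number modestly. Neither of them brings in a piperazine, so they give a size rather than a firm direction. A small to modest step is therefore expected, leaning towards a lower number, and the opposite direction is not excluded. The estimated change is small (a 1.7-fold lower number from compound 3 to compound 4 (0.22 log units; within the scatter)). For compound 4 the estimated value is 150 nM (expected range 40 nM to 550 nM).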

Compound 4, half-maximal inhibitory concentration: 700 nM
Compound 4: the middle estimate sits 4.7-fold (0.67 log units) below what was measured; the measured number lies above the stated range.
By their numbers in this assay, from the lowest: compound 2; then compounds 3, 1 and 4 (each within the scatter of the next, the first and the last beyond it).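

Both readings of this exchange come from a single change on a saturated chain carbon bound to an aromatic nitrogen, and they do not carry the same weight: a 2.8-fold higher number from compound 3 to compound 4 (0.45 log units; beyond the scatter) in this assay, while a 1.8-fold higher number from compound 1 to compound 4 (0.24 log units; within the scatter) in the same assay. For the compounds shown here, compound 4 is the first compound here without the triazole at this position, and neither step shows a gain from the 4-(piperazin-1-yl)butyl chain, so the earlier changes at the diol end, which all kept the triazole, gave no guide to the direction of this one. Nothing in the data shown explains why the number moves with this exchange.

The compounds shown leave open which part of the exchange matters, since the triazole, the diol and the chain length all change together, and a compound that keeps the triazole and carries a piperazine in place of the diol would begin to separate them. They also leave open how a shorter chain ending in piperazine, or a morpholine or a primary amine at the chain end, would read in this assay.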